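The source may report more compounds than this note shows. Statements on the series, on what has been measured and on what is new or still open speak of the compounds shown alone.

Measured compounds in a functional assay on A549 cells (Homo sapiens) for inhibition, read by MTT assay, with a stated time of 48 h; on this read-out lower numbers stand for stronger inhibition and higher numbers for weaker inhibition:
Compound 1, `Cn1cc(NC(=O)c2cccc(NS(=O)(=O)c3ccccc3)c2)cn1`. In this assay compound 1 gives > 100000 nM, which is a limit of the assay and not a number.
Compound 2, `O=C(Nc1cnn(-c2ccccc2)c1)c1cccc(NS(=O)(=O)c2ccccc2)c1`. In this assay compound 2 gives 26800 nM.
Compound 3, `Cc1ccc(-n2cc(NC(=O)c3cccc(NS(=O)(=O)c4ccccc4)c3)cn2)cc1`. In this assay compound 3 gives 18900 nM.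

Compound 3 and compound 2 lie within the scatter of each other, the step between them being a 1.4-fold lower number from compound 2 to compound 3 (0.15 log units; within the scatter). Compound 1 alone sits at the limit of > 100000 nM in this assay, at which 1 of the 3 values shown sits. From compound 1 the steps are an at least 3.7-fold lower number from compound 1 to compound 2 (0.57 log units; beyond the scatter) and an at least 5.2-fold lower number from compound 1 to compound 3 (0.72 log units; beyond the scatter), both beyond the scatter.

Compound 4, `COc1cccc(-n2cc(NC(=O)c3cccc(NS(=O)(=O)c4ccccc4)c3)cn2)c1`, has not yet been measured in this assay. It differs from compound 3 in one place: 3-methoxyphenyl in place of 4-methylphenyl on an aromatic nitrogen. Within the data shown here, the steps that bear on this change are those in which the group on the aromatic nitrogen is varied. Replacing methyl by either aryl group gave an at least modest step, whereas phenyl and 4-methylphenyl gave numbers within the scatter of each other. A third aryl group on the same nitrogen is therefore expected to behave much like the first two, and the expected step is a 1.1-fold higher number from compound 3 to compound 4 (0.02 log units; within the scatter), not beyond the scatter. Compound 4 is estimated at 20000 nM, with a range from 8000 nM to 50000 nM.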

Compound 4, half-maximal inhibitory concentration: 81100 nM
Compound 4: middle estimate off by 4.1-fold (0.61 log units), on the low side; the whole stated range lies below it.
By their numbers in this assay, from the lowest: compounds 3 and 2 (each within the scatter of the next); then compound 4. At a limit, above all of these: compound 1.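

On the aromatic nitrogen, aryl groups are not interchangeable: adding methoxy to the phenyl group gives a 3.0-fold higher number from compound 2 to compound 4 (0.48 log units; beyond the scatter), and exchanging 4-methylphenyl for 3-methoxyphenyl gives a 4.3-fold higher number from compound 3 to compound 4 (0.63 log units; beyond the scatter), whereas phenyl and 4-methylphenyl had stayed within the scatter of each other. The gain seen earlier on replacing methyl with an aryl group therefore does not extend to every aryl group, as compound 4 shows only an at least 1.2-fold lower number from compound 1 to compound 4 (0.09 log units; that floor lies within the scatter). That step has only a floor, and the value of compound 1 is a limit and not a number: the limit of > 100000 nM in this assay, at which 1 of the 4 values shown sits.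

From the compounds shown here alone, what stays open is whether the methoxy group itself or its place on the ring matters, which 4-methoxyphenyl and 3-methylphenyl groups could separate. Going by these compounds, how an amine or a carboxylic acid on that phenyl ring would behave also remains open.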